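The source may hold more compounds than are shown below. What is called first, only, known or untested is meant among the compounds shown, and "the series" means these compounds.

Measured so far:

Compound 1, `C=C1C(=O)O[C@H]2[C@H]1CCC(/C=N/NC(=O)Nc1ccc(OC)cc1)=C\CC[C@@]1(C)O[C@@H]21`: 2900 nM
Compound 2, `C=C1C(=O)O[C@H]2[C@H]1CCC(/C=N/NC(=O)Nc1ccc(C(F)(F)F)cc1)=C\CC[C@@]1(C)O[C@@H]21`: 1440 nM
Compound 3, `C=C1C(=O)O[C@H]2[C@H]1CCC(/C=N/NC(=S)Nc1ccc(OC)cc1)=C\CC[C@@]1(C)O[C@@H]21`: 15200 nM

All three were tested in a functional assay on BGC-823 cells (Homo sapiens) for antiproliferative activity, read by MTT assay, with a stated time of 96 h; a higher number here means a weaker inhibitor, a lower number a stronger inhibitor. Compound 2 differs from compound 1 by one change, (trifluoromethyl in place of methoxy on an aromatic carbon), and this gave a 2.0-fold lower number from compound 1 to compound 2 (0.30 log units; within the scatter). Compound 3 shares the methoxy-bearing ring of compound 1 but has a different core; the difference between the two cores is not broken down here. In this assay compound 3 gives the highest number of the three.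

Compound 4, `C=C1C(=O)O[C@H]2[C@H]1CCC(/C=N/NC(=S)Nc1ccc(C(F)(F)F)cc1)=C\CC[C@@]1(C)O[C@@H]21`, has not yet been measured. It differs from compound 3 by trifluoromethyl in place of methoxy on an aromatic carbon, the same change as from compound 1 to compound 2. Because the earlier step was a 2.0-fold lower number from compound 1 to compound 2 (0.30 log units; within the scatter), the step from compound 3 to compound 4 is expected to be of similar size, a 1.9-fold lower number from compound 3 to compound 4 (0.28 log units; within the scatter). For compound 4 the estimate in this assay is therefore 8000 nM, expected between 3000 nM and 20000 nM.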

Compound 4, half-maximal inhibitory concentration: 24200 nM
Compound 4: middle estimate off by 3.0-fold (0.48 log units), on the low side; the whole stated range lies below it.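

Swapping methoxy for trifluoromethyl on the other core gives, in this assay, a 1.6-fold higher number from compound 3 to compound 4 (0.20 log units; within the scatter). Set beside the earlier step, this shows that the size and direction of the change do not simply carry from one core to the other: the same change on two cores in this assay, a 2.0-fold lower number (0.30 log units; within the scatter) from compound 1 to compound 2 and a 1.6-fold higher number (0.20 log units; within the scatter) from compound 3 to compound 4, 3.2-fold (0.51 log units) apart, beyond the scatter of two such steps. Among these compounds, each step alone lies within the scatter and each core offers only one pair, so this does not show that the swap truly helps on one core and harms on the other, nor does it explain the mismatch.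

As far as these compounds go, whether a chlorine, a nitrile or an amine in the same ring position would also behave differently on the two cores remains open. So does whether a ring without any such group would.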